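The source may hold more compounds than are shown below. What is called first, only, known or untested is meant among the compounds shown, and "the series" means these compounds.

Working notes on the cytotoxicity series. For the measured compounds named here, compound 1 `CCCNC(=O)C1CC12CCN(C(=O)c1cc3sc(Br)nc3n1Cc1ccc(OC)cc1)CC2` is the only member of the set with a number: in an ADME assay on HEK-293T cells (Homo sapiens) for cytotoxicity, read by luminescence and CellTiter-Glo, with a stated time of 24 h (a higher number here means that more compound is tolerated, a lower number that less compound is tolerated), compound 1 gives 81300 nM. Going by the values given here, compound 2 `CCCNC(=O)C1CCN(C(=O)c2cc3sc(Br)cc3n2Cc2ccc(OC)cc2)CC1` carries the same amide and methoxybenzyl pieces on a different core, and no single counted step connects it to compound 1. In this assay compound 2 gives only a limit of the assay, > 100000 nM; > 100000 nM (2 entries), and not a number. Taken together, the two values show that both compounds are tolerated at high concentration, with compound 1 the only one pinned to a value.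

Compound 3 `CCCNC(=O)C1CC12CCN(C(=O)c1cc3sc(-c4ccccc4)nc3n1Cc1ccc(OC)cc1)CC2` is compound 1 with phenyl in place of bromo on an aromatic carbon. Among the compounds with values here, no measured pair in the set shows a change of this kind, so the size of the move in this assay cannot be read from data. The expected step is a 1.6-fold lower number from compound 1 to compound 3 (0.21 log units; within the scatter), a modest shift toward less compound tolerated, of a size that may not clearly exceed the scatter. Compound 3 is accordingly estimated at 50000 nM in this assay, with a range from 20000 nM to 100000 nM.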

Compound 3, half-maximal cytotoxic concentration: > 100000 nM
Compound 3: only a limit was reported; the forecaster's own chance of this, stated with the estimate: 25%; middle value at least 2.0-fold (0.30 log units) from the limit.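

Phenyl in place of bromo on an aromatic carbon, next to the ring nitrogen and next to the ring sulfur, is the first change at this position among the compounds shown, and in this assay it gives an at least 1.2-fold higher number from compound 1 to compound 3 (0.08 log units; that floor lies within the scatter). Replacing a single bromine with a six-membered aromatic ring of carbon only therefore brings no visible move toward less compound tolerated, although the floor of this step does not by itself separate compound 3 from compound 1. The true size of the step cannot be read, because the result for compound 3 is a limit of the assay and not a number: the limit of > 100000 nM in this assay, at which 1 of the 3 values shown sits.

The compounds shown carry only bromo and phenyl at this position, so they leave open how an amine, a carboxylic acid or a longer alkyl chain there would behave in this assay. For the compounds shown here, also open is the contribution of the core, as no single step joins compound 2 to compound 1 or compound 3.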